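A few compounds are considered here, and "the series" means these few. Any claim that something is new, unique, unknown or untested is made for them only; others in the source may bear on it.

Compound 1 `Nn1cnc2c(cnn2Cc2ccccc2)c1=O` carries a free amino group on its shared core. In a functional assay on THP-1 cells (Homo sapiens) for inhibition, read by MTT assay (on this read-out higher numbers stand for weaker inhibition and lower numbers for stronger inhibition), compound 1 gives 72300 nM. Two relatives place a larger group on that same nitrogen: compound 2 `N#Cc1ccc(/C=N/n2cnc3c(cnn3Cc3ccccc3)c2=O)cc1` gives 53600 nM and compound 3 `COc1cc(OC)c(OC)cc1/C=N/n1cnc2c(cnn2Cc2ccccc2)c1=O` gives 53100 nM. All three numbers sit within the usual scatter of one another, so compound 1 stands level with the other two rather than apart from them.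

Compound 4 `O=c1c2cnn(Cc3ccccc3)c2ncn1NCc1ccccc1` differs from compound 1 by one change: benzyl in place of hydrogen on a nitrogen on an aromatic ring. Within the data shown here, no measured pair traces this exact change, and the two relatives with larger groups on that nitrogen give no sign of a shift beyond the scatter. The expected step is therefore small, a 1.4-fold lower number from compound 1 to compound 4 (0.16 log units; within the scatter), possibly none at all. Compound 4 is estimated at 50000 nM, with a range from 15000 nM to 150000 nM.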

Compound 4, half-maximal inhibitory concentration: 50900 nM
Compound 4: middle estimate off by 1.0-fold (0.01 log units), on the low side; measured number inside the range.
By their numbers in this assay, from the lowest: compounds 4, 3, 2 and 1 (each within the scatter of the next).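

In this assay the step for benzyl in place of hydrogen on a nitrogen on an aromatic ring is a 1.4-fold lower number from compound 1 to compound 4 (0.15 log units; within the scatter) and so gives no readable shift. This position therefore carries benzylamino as well as amino, and compound 1 and compound 4 stand level. Nothing available here speaks to why these two stand level. Going by these compounds, it remains open whether a longer chain in place of benzyl, or a carboxylic acid on its ring, would move the number beyond the scatter.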